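The source may hold more compounds than are shown below. What is called first, only, known or untested is meant among the compounds shown, and "the series" means these compounds.

Compound 1, `C=CCO/N=C/c1c(N)ncnc1Oc1ccc(NC(=O)C2(C(=O)Nc3ccc(F)cc3)CC2)cc1F`, gives 3.65 in a physicochemical assay for lipophilicity, using the shake flask method; on this read-out higher numbers stand for higher lipophilicity and lower numbers for lower lipophilicity.
Compound 2, `Nc1ncnc(Oc2ccc(NC(=O)C3(C(=O)Nc4ccc(F)cc4)CC3)cc2F)c1/C=N/OCc1ccccc1`, gives 4.45 in this assay.
Compound 3, `Nc1ncnc(Oc2ccc(NC(=O)C3(C(=O)Nc4ccc(F)cc4)CC3)cc2F)c1/C=N/OCC(=O)N1CCOCC1`, gives 2.1 in this assay.

Compound 3 stands lowest of the three measured compounds, with compound 1 nearest and compound 2 furthest away, both separated from it by more than the usual scatter. The unmeasured compound 4, `Nc1ncnc(Oc2ccc(NC(=O)C3(C(=O)Nc4ccc(F)cc4)CC3)cc2F)c1/C=N/OC1CCCC1`, differs from compound 3 in one place: cyclopentyl in place of ((morpholin-4-yl)carbonyl)methyl on an oxygen. For the measured compounds named here, two measured steps bear on this change, since both take away the same morpholinylcarbonyl piece: a number 1.55 log units lower from compound 1 to compound 3 (beyond the scatter), and a number 2.35 log units lower from compound 2 to compound 3 (beyond the scatter). Read in reverse, they show that losing this piece raised the number by a large amount in both cases, and the step of a number 0.80 log units higher from compound 1 to compound 2 (beyond the scatter) shows that a ring in this place gives a higher number than a short open chain. Cyclopentyl in place of the ((morpholin-4-yl)carbonyl)methyl group is therefore expected to give a large upward step in this assay. Compound 4 is expected to reach 4.2, with a range from 3.7 to 4.7. This estimate means an expected step of a number 2.10 log units higher from compound 3 to compound 4 (beyond the scatter).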

Compound 4, partition coefficient: 4.27
For compound 4 the middle estimate is 0.07 log units below the measured one; measured number inside the range.
By their numbers in this assay, from the lowest: compound 3; then compound 1; then compounds 4 and 2 (each within the scatter of the next).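

In this assay, for the compounds shown here, the earlier compounds showed that the group on the oxygen bound to the double-bonded nitrogen can move the number a long way, and compound 4 adds a group made of carbon only, with a number 2.17 log units higher from compound 3 to compound 4 (beyond the scatter). Cyclopentyl and benzyl cannot be told apart here, with a number 0.18 log units lower from compound 2 to compound 4 (within the scatter), so an aromatic ring on this oxygen is not needed to reach this level in these compounds. Cyclopentyl in place of allyl gives a number 0.62 log units higher from compound 1 to compound 4 (beyond the scatter), which fits a ring standing higher than the open chain, although compound 3 goes against any rule about rings alone, since it carries a morpholine ring and stands lowest.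

Going by these compounds, whether a basic amine on the chain, a carboxylic acid or a longer carbon chain such as hexyl would keep the number at this level or lower it remains open. No measurement shown here explains any of these steps.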